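A few compounds are considered here, and "the series" means these few. Any claim that something is new, unique, unknown or untested is made for them only; others in the source may bear on it.

Working notes on the series. Compound 1 `COC(=O)c1cc(-c2cccc(NC(=O)c3ccc(/C=C/C(=O)c4ccc(C)c(F)c4)cc3)c2)on1`, compound 2 `COC(=O)c1cc(-c2cccc(NC(=O)c3ccc(/C=C/C(=O)c4ccc(Cl)cc4Cl)cc3)c2)on1` and compound 3 `COC(=O)c1cc(-c2cccc(NC(=O)c3ccc(/C=C/C(=O)c4ccc(Cl)cc4)cc3)c2)on1` share one core and differ only in the group on a carbonyl carbon. In an ADME assay on Vero cells (Chlorocebus sabaeus) for cytotoxicity, read by MTT assay, with a stated time of 72 h (on this read-out higher numbers stand for lower toxicity in this test and lower numbers for higher toxicity in this test), compound 1 gives > 50 ug/mL, which is a limit of the assay and not a number. In this assay compound 2 gives > 40 ug/mL, likewise a limit. In this assay compound 3 gives > 50 ug/mL, again a limit. Compound 3 thus stands only at a limit, as do the two other values shown, and the steps a step that the two limits leave unreadable from compound 1 to compound 2, a step that the two limits leave unreadable from compound 1 to compound 3 and a step that the two limits leave unreadable from compound 2 to compound 3 cannot be sized because the limit of > 50 ug/mL in this assay, at which 2 of the 3 values shown sit, and the limit of > 40 ug/mL in this assay, at which 1 of the 3 values shown sits, cap every value. Compound 4 `COC(=O)c1cc(-c2cccc(NC(=O)c3ccc(/C=C/C(=O)c4ccc(OC)c([N+](=O)[O-])c4)cc3)c2)on1` is defined by 4-methoxy-3-nitrophenyl in place of 4-chlorophenyl on a carbonyl carbon. All three measured steps concern the same place and bear on this change, but none is readable, so no step beyond the scatter is expected in this assay. The expected step in this assay is a number no higher from compound 3 to compound 4 (the limit leaves the size open). Compound 4 is estimated at 50 ug/mL in this assay, between 30 ug/mL and 100 ug/mL, most likely reported only as a limit.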

Compound 4, half-maximal cytotoxic concentration: > 40 ug/mL
Compound 4: no number, only a limit; the forecaster's own chance of this, stated with the estimate: 80%; the middle value does not contradict the limit.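

The steps from compound 1, compound 2 and compound 3 to compound 4 cannot be read, since all four values are limits of the assay and not numbers. The compounds shown leave open whether the group on a carbonyl carbon changes the half-maximal cytotoxic concentration at all.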